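Hydroxy for hydrogen on the saturated chain carbon

This account rests on a few compounds, and the source may have more. Where it says the series, first, only, none or still open, it means among the compounds named here.

The series is read in a functional assay on HT-29 cells (Homo sapiens) for cytotoxicity, read by XTT assay, with a stated time of 72 h; a higher number here means a weaker inhibitor, a lower number a stronger inhibitor. Among the compounds with values here, compound 1 `CCn1ccc2cc(Cc3cc(OC)c(OC)c(OC)c3)ccc21` is the only member with a number: in this assay compound 1 gives 35 nM. Compound 2 `COc1ccc(Cc2ccc3ccccc3c2)c(OC)c1OC` keeps the saturated chain carbon bound to two aromatic carbons but sits on another core; the difference between the two cores is not broken down here. In this assay compound 2 reaches only a limit of the assay, > 10000 nM. Compound 3 `COc1ccc(C(O)c2ccc3ccccc3c2)c(OC)c1OC` carries the change (hydroxy in place of hydrogen on a saturated chain carbon bound to two aromatic carbons). In this assay compound 3 likewise gives only a limit, > 10000 nM. The step that the two limits leave unreadable from compound 2 to compound 3 therefore cannot be read, and the limit of > 10000 nM in this assay, at which 2 of the 3 values shown sit, marks where both values sit.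

Compound 4 `CCn1ccc2cc(C(O)c3cc(OC)c(OC)c(OC)c3)ccc21` is not yet measured. It stands to compound 1 as compound 3 stands to compound 2: the change is hydroxy in place of hydrogen on a saturated chain carbon bound to two aromatic carbons, at the same place, so it is the same change, occurring twice among these compounds. Within the data shown here, the one measured instance gives neither size nor direction, and nothing else among the compounds bears on it. The expectation for compound 4 is anchored only because compound 1 gives 35 nM in this assay. Compound 4 is expected near 150 nM, between 30 nM and 1500 nM. The expected step is a 4.3-fold higher number from compound 1 to compound 4 (0.63 log units; beyond the scatter), kept wide as the measured case offers no guide.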

Compound 4, half-maximal inhibitory concentration: > 10000 nM
Compound 4: only a limit was reported; the forecaster's own chance of this, stated with the estimate: 5%; at least 66-fold (1.82 log units) between middle value and limit.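

Within the data shown here, on the core of compound 1, hydroxy in place of hydrogen on a saturated chain carbon bound to two aromatic carbons gives an at least 280-fold higher number from compound 1 to compound 4 (2.45 log units; beyond the scatter) in this assay; this is the only readable instance of the change, and it is a large, unfavourable one, with compound 4 ending at a limit of the assay rather than at a number. The same change on the other core cannot be read, as compound 2 and compound 3 both stand at that limit, so the series shows neither that the size of the step carries from one core to the other nor that it fails to. All that the two instances share is where the hydroxy compounds end, and this is a shared limit, not an equal effect: the limit of > 10000 nM in this assay, at which 3 of the 4 values shown sit.

Whether the step belongs to the hydroxy group itself or would come with any other group on that carbon stays open, as the compounds shown carry no amine, fluoro or methoxy group at this place. Also open, from the compounds shown here alone, is how large the true step from compound 1 to compound 4 is, as only its lower bound can be read.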